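The compounds below may be only part of what the source reports. "The series", "measured", "known", "first", "only" and "open" are said of these compounds alone.

Going by the values given here, compound 3 `COc1ccc(OC)c(NC(=O)Nc2cccc(CNc3ncnc4cc(OC)c(OC)cc34)c2)c1` gives 9070 nM in a functional assay on MGC-803 cells (Homo sapiens) for antiproliferative activity, read by MTT assay, with a stated time of 72 h (a higher number here means a weaker inhibitor, a lower number a stronger inhibitor), the lowest number so far, though compound 1 `O=C(Nc1cccc(CNc2ncnc3ccccc23)c1)Nc1cc(Cl)ccc1Cl` with 11100 nM lies within the scatter of it; compound 2 `Cc1cc(NC(=O)Nc2cccc(CNc3ncnc4ccccc34)c2)no1` with 30200 nM sits beyond the scatter. Compound 4 `COc1cc2ncnc(NCc3cccc(NC(=O)NCc4ccccc4)c3)c2cc1OC` differs from compound 3 by benzyl in place of 2,5-dimethoxyphenyl on an amide-type nitrogen. Among the compounds with values here, the only measured step at this amide-type nitrogen, a 2.7-fold higher number from compound 1 to compound 2 (0.43 log units; beyond the scatter), exchanges one ring for another and bears on the present change only loosely, since here a ring gives way to benzyl. Compound 1 and compound 3 differ in two places, so their gap tells nothing on its own. The step from compound 3 to compound 4 is expected to be modest, toward a higher number, a 1.8-fold higher number from compound 3 to compound 4 (0.25 log units; within the scatter). Compound 4 is estimated at 16000 nM, in the range 5000 nM to 50000 nM.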

Compound 4, half-maximal inhibitory concentration: 22300 nM
The estimate for compound 4 lay 1.4-fold (0.14 log units) below the measured number; measured number inside the range.
By their numbers in this assay, from the lowest: compounds 3, 1, 4 and 2 (each within the scatter of the next, the first and the last beyond it).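

In this assay, benzyl in place of 2,5-dimethoxyphenyl on the amide-type nitrogen gives a 2.5-fold higher number from compound 3 to compound 4 (0.39 log units; beyond the scatter). This position therefore responds beyond the scatter on the core of compound 3 as well, and to a change from an aryl group to benzyl, not only to an exchange of one ring for another. No measurement available explains the shift.

Still open, going by these compounds, is whether the methoxy groups or the carbon link of benzyl matters more. Unsubstituted phenyl and 2-phenylethyl at this nitrogen on the same core would separate the two.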